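The source may report more compounds than this note shows. Statements on the series, on what has been measured and on what is new or still open speak of the compounds shown alone.

In a functional assay on MCF7 cells (Homo sapiens) for cytotoxicity, read by MTT assay, with a stated time of 48 h (on this read-out lower numbers stand for stronger inhibition and higher numbers for weaker inhibition), three related compounds have been measured so far. Compound 2 (`C/C(=N/NC(=S)Nc1ccccc1)c1ccccn1`) gives 0.18 nM, the lowest of the three and clear of the others beyond the scatter. Compound 1 (`C/C(=N\NC(=S)Nc1cccc(F)c1)c1ccccn1`) gives 9 nM, and compound 3 (`C/C(=N/NC(=S)Nc1cccc([N+](=O)[O-])c1)c1ccccn1`) gives 38 nM.

Compound 4 (`C/C(=N\NC(=S)Nc1ccccc1)c1ccccn1`) is compound 2 with one change: the two compounds have the same atoms and bonds and differ only in configuration as drawn: 1 of 1 stereo elements differ; a double bond is drawn Z in compound 2 and E in compound 4. Among the measured compounds shown here, no measured step isolates a change of this kind. For the measured compounds named here, the only measured step, a 210-fold higher number from compound 2 to compound 3 (2.32 log units; beyond the scatter), swaps in a nitro group instead, so it shows only that a single change can move the number a long way here.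

Compound 1 offers a closer hint, since it is also drawn E, although it carries a fluorine as well. With compound 1 at 9 nM, a higher number is expected for the E form, but the size is uncertain. The expected change is an 8.3-fold higher number from compound 2 to compound 4 (0.92 log units; beyond the scatter). Compound 4 is estimated at 1.5 nM, with an expected range from 0.1 nM to 25 nM.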

Compound 4, half-maximal inhibitory concentration: 0.18 nM
Compound 4: middle estimate off by 8.3-fold (0.92 log units), on the high side; low and high end bracket the measured number.
By their numbers in this assay, from the lowest: compounds 2 and 4 (each within the scatter of the next); then compound 1; then compound 3.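

In this assay, changing the drawn configuration of the double bond gives no change at the digits printed from compound 2 to compound 4 (within the scatter), so this change, unlike the nitro swap, leaves the number in place. Compound 4 also gives a cleaner reading of the fluoro group. It shares its E drawing with its fluorinated partner: hydrogen in place of fluoro gives a 50-fold lower number from compound 1 to compound 4 (1.70 log units; beyond the scatter). The high number of compound 1 therefore goes with the fluoro group and not with the E drawing, and the comparison of the two configurations is a clean one for this reason: the fact that compounds 2 and 4 differ only in the configuration as drawn

As far as these compounds go, only the compounds without fluoro or nitro appear in both configurations, so it remains open whether those two groups would also tolerate the change. From the compounds shown here alone, how an amine or a methoxy group at the same place would compare also remains open.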